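Series notes: chain substituent step from compound 3 to compound 4

A few compounds are considered here, and "the series" means these few. Any claim that something is new, unique, unknown or untested is made for them only; others in the source may bear on it.

Compound 1 `CC/C=C\Cn1c(Cc2cc(OC)c(OC)c(OC)c2)nc2c(N)ncnc21`, compound 2 `COc1cc(Cc2nc3c(N)ncnc3n2CCCC(C)C)cc(OC)c1OC` and compound 3 `CCn1c(Cc2cc(OC)c(OC)c(OC)c2)nc2c(N)ncnc21` share one core and differ only in the group on a saturated chain carbon bound to an aromatic nitrogen. In a functional assay on MCF7 cells (Homo sapiens) for antiproliferative activity (on this read-out lower numbers stand for stronger inhibition and higher numbers for weaker inhibition), compound 1 gives 64600 nM, compound 2 gives 69200 nM and compound 3 gives 79400 nM. Compound 3 has the highest of the three numbers, but all gaps lie within the scatter. Compound 4 `COc1cc(Cc2nc3c(N)ncnc3n2CC(OC)OC)cc(OC)c1OC` carries dimethoxymethyl in place of methyl on a saturated chain carbon bound to an aromatic nitrogen. Every measured step bears on this change, each altering the same chain position: a 1.1-fold higher number from compound 1 to compound 2 (0.03 log units; within the scatter), a 1.2-fold higher number from compound 1 to compound 3 (0.09 log units; within the scatter) and a 1.1-fold higher number from compound 2 to compound 3 (0.06 log units; within the scatter), none beyond the scatter. For compound 4 a step of a 1.1-fold lower number from compound 3 to compound 4 (0.02 log units; within the scatter) is therefore expected, within the scatter. The estimate for compound 4 in this assay is 75000 nM, range 40000 nM to 140000 nM.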

Compound 4, half-maximal inhibitory concentration: 72400 nM
Compound 4: the middle estimate sits 1.0-fold (0.02 log units) above what was measured; the range from low to high includes it.
By their numbers in this assay, from the lowest: compounds 1, 2, 4 and 3 (each within the scatter of the next).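

In this assay, among the compounds shown here, dimethoxymethyl is the first group on this saturated chain carbon to bring in oxygen and hydrogen-bond acceptors, yet every new step stays within the scatter (a 1.1-fold lower number from compound 3 to compound 4 (0.04 log units; within the scatter)) and (a 1.0-fold higher number from compound 2 to compound 4 (0.02 log units; within the scatter)) and (a 1.1-fold higher number from compound 1 to compound 4 (0.05 log units; within the scatter)). The position thus shows no measurable response to this change, any more than it did among the hydrocarbon groups of compound 1, compound 2 and compound 3. No supporting data bear on this result.

As far as these compounds go, whether an amine, a carboxylic acid or a phenyl ring at this position would give a step beyond the scatter remains open. Also open, from the compounds shown here alone, is whether the flat response holds for a change elsewhere on the shared core.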